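The compounds below may be only part of what the source reports. "The series", "measured", "known", "first", "only" and "open" are said of these compounds alone.

Measured compounds in an ADME assay on the whole organism with Oryza sativa as the target, tested at 0.1 uM; on this read-out lower numbers stand for a stronger effect and higher numbers for a weaker effect at the one concentration tested:
- compound 1 `CC(C)c1cccc(NC(=O)N[C@H](C)c2ccccc2)c1` gives 74%
- compound 2 `CC(C)c1cccc(NC(=O)N[C@@H](C)c2ccccc2)c1` gives 95%
- compound 3 `CCCCc1ccc(NC(=O)N[C@@H](C)c2ccccc2)cc1` gives 98%

Among these three numbers compound 2 holds the second highest place. Compound 3 sits within the scatter of compound 2, so the two cannot be told apart. Compound 1 stands clearly apart: the change is a number 21 percentage points higher from compound 1 to compound 2 (beyond the scatter), and this rests on (the fact that compounds 1 and 2 differ only in the configuration as drawn), nothing else in the molecule being altered.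

Compound 4 `C[C@H](NC(=O)Nc1cccc(I)c1)c1ccccc1` has not yet been measured. It differs from compound 2 by iodo in place of isopropyl on an aromatic carbon. Among the compounds with values here, no measured step touches a swap of this kind; the only step known, from compound 1 to compound 2, concerns configuration alone, so it gives no guide to replacing one group on the ring with another. Without a bearing step, no change beyond the scatter is expected in this assay, in either direction. Compound 4 is therefore estimated at about 92%, with a range from 70% to 100%. The expected step is a number 3 percentage points lower from compound 2 to compound 4 (within the scatter).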

Compound 4, a percentage reported as activity, at one concentration (the size of the read-out at that concentration, not a potency): 98%
The estimate for compound 4 lay 6 percentage points below the measured number; measured number inside the range.
By their numbers in this assay, from the lowest: compound 1; then compounds 2, 3 and 4 (each within the scatter of the next).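

In this assay, iodo in place of isopropyl on an aromatic carbon gives a number 3 percentage points higher from compound 2 to compound 4 (within the scatter), so compound 2 and compound 4 cannot be told apart. This is the first step shown at a ring group rather than in configuration, and it shows that, for this pair, one iodine atom can stand where three carbon atoms stood without the read-out leaving the scatter. Nothing measured here accounts for this result.

From the compounds shown here alone, whether an amine or a carboxylic acid on this aromatic carbon would give a number beyond the scatter of compound 2 remains open. Also open, going by these compounds, is whether iodo combined with the configuration drawn in compound 1 would give a number near that of compound 1, which gives 74%.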